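The source may report more compounds than this note shows. Statements on the series, on what has been measured and on what is new or still open speak of the compounds shown alone.

Measured so far:
compound 1 `COc1cccc(OC)c1OCCNCCOc1ccccc1OCc1ccc(Cl)cc1` — 1 nM
compound 2 `COc1cccc(OC)c1OCCNCCOc1ccccc1OCc1ccccc1C` — 0.794 nM
compound 3 `COc1cccc(OC)c1OCCNCCOc1ccccc1OCc1cccc([N+](=O)[O-])c1` — 0.794 nM

These three compounds share one core and differ only in the aromatic group held on a saturated chain carbon bound to an oxygen on an aromatic ring. All were tested in an assay on CHO cells for displacement of a labelled ligand from Alpha-1B adrenergic receptor (Homo sapiens); on this read-out higher numbers stand for weaker inhibition and lower numbers for stronger inhibition. Compound 3 stands level with compound 2, and together they give the lowest of the three numbers; the step of a 1.3-fold lower number from compound 1 to compound 3 (0.10 log units; within the scatter), like no change at the digits printed from compound 2 to compound 3 (within the scatter) and a 1.3-fold lower number from compound 1 to compound 2 (0.10 log units; within the scatter), lies within the scatter, so the three numbers cannot be told apart.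

Compound 4 `COc1ccccc1COc1ccccc1OCCNCCOc1c(OC)cccc1OC` has not yet been measured. It differs from compound 3 in one place: 2-methoxyphenyl in place of 3-nitrophenyl on a saturated chain carbon bound to an oxygen on an aromatic ring. Among the compounds with values here, the steps that bear on this change are the earlier swaps of the same group on the same carbon, a 1.3-fold lower number from compound 1 to compound 3 (0.10 log units; within the scatter) and no change at the digits printed from compound 2 to compound 3 (within the scatter). Both stayed within the scatter, so for this further swap no step beyond the scatter is expected in this assay , in either direction.

Compound 4 is therefore estimated at 0.9 nM, with a range from 0.3 nM to 3 nM. The expected step is a 1.1-fold higher number from compound 3 to compound 4 (0.05 log units; within the scatter).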

Compound 4, inhibition constant: 6.31 nM
The estimate for compound 4 lay 7.0-fold (0.85 log units) below the measured number; the measured number lies above the stated range.
By their numbers in this assay, from the lowest: compounds 2, 3 and 1 (each within the scatter of the next); then compound 4.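

Within the data shown here, until this result, the aromatic group on a saturated chain carbon bound to an oxygen on an aromatic ring could be changed with no step beyond the scatter in this assay, but 2-methoxyphenyl breaks that picture, giving a 7.9-fold higher number from compound 3 to compound 4 (0.90 log units; beyond the scatter) and a 6.3-fold higher number from compound 1 to compound 4 (0.80 log units; beyond the scatter). The sharpest comparison is with the 2-methylphenyl group, where methoxy in place of methyl on an aromatic carbon is the only difference and gives a 7.9-fold higher number from compound 2 to compound 4 (0.90 log units; beyond the scatter), so the earlier agreement among the 4-chlorophenyl, 2-methylphenyl and 3-nitrophenyl groups does not extend to every aromatic group at this place. Nothing available here accounts for this step.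

The compounds shown leave open whether the higher number belongs to methoxy alone or also appears with other groups on the same aromatic carbon, such as hydroxy, ethoxy or an amine. They also leave open whether an unsubstituted phenyl group would fall with compounds 1, 2 and 3 or with compound 4.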